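This account rests on a few compounds, and the source may have more. Where it says the series, first, only, none or still open, it means among the compounds named here.

The compounds measured in an ADME assay on a cell-free system (plasma, Rattus norvegicus) for metabolic stability, read by LC-MS, with a stated time of 60 min, at 37 degrees C, tested at 50 uM (a lower number here means that less of the compound is left, a higher number that more of the compound is left), so far:

compound 1, `C[C@@H](O)[C@H]1C(=O)N2C(C(=O)OCOC(=O)OC(C)(C)C)=C(S[C@@H]3CN[C@H](C(=O)Nc4cccc(C(=O)O)c4)C3)[C@H](C)[C@H]12`, with 0%
compound 2, `CCOC(=O)OCOC(=O)C1=C(S[C@@H]2CN[C@H](C(=O)Nc3cccc(C(=O)O)c3)C2)[C@H](C)[C@@H]2[C@@H]([C@@H](C)O)C(=O)N12`, with 0%
compound 3, `C[C@@H](O)[C@H]1C(=O)N2C(C(=O)OCC(F)(F)F)=C(S[C@@H]3CN[C@H](C(=O)Nc4cccc(C(=O)O)c4)C3)[C@H](C)[C@H]12`, with 7%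

Compound 3 holds the highest of the three numbers, yet its lead is small: the step of a number 7 percentage points higher from compound 1 to compound 3 (within the scatter) and the step of a number 7 percentage points higher from compound 2 to compound 3 (within the scatter) both stay within the scatter, so compound 3 cannot be called more stable than compound 1 or compound 2 in this assay. The step of no change at the digits printed from compound 1 to compound 2 (within the scatter) likewise shows nothing beyond the scatter.

Compound 4, `COC(=O)OCOC(=O)C1=C(S[C@@H]2CN[C@H](C(=O)Nc3cccc(C(=O)O)c3)C2)[C@H](C)[C@@H]2[C@@H]([C@@H](C)O)C(=O)N12`, is the next compound in this series. Relative to compound 3 the change is (methoxycarbonyl)oxy in place of trifluoromethyl on a saturated chain carbon bound to an oxygen next to a carbonyl group. Read one bond further out, 2,2,2-trifluoroethoxy becomes ((methoxycarbonyl)oxy)methoxy, which brings compound 4 close to compound 1 and compound 2, where (tert-butoxycarbonyl)oxy and (ethoxycarbonyl)oxy occupy the same place. Within the data shown here, the steps that bear on this move are therefore the step of a number 7 percentage points higher from compound 2 to compound 3 (within the scatter) and the step of a number 7 percentage points higher from compound 1 to compound 3 (within the scatter), both small and within the scatter, and the step of no change at the digits printed from compound 1 to compound 2 (within the scatter), which shows that swapping the group on the oxygen next to the carbonyl group changed nothing. Compound 4 is expected to fall back toward the numbers of compound 1 and compound 2, with the step of a number 5 percentage points lower from compound 3 to compound 4 (within the scatter) not reaching beyond the scatter. The estimate for compound 4 in this assay is 2%, within a range from 0% to 10%.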

Compound 4, percent of the compound remaining: 0%
Compound 4: the middle estimate sits 2 percentage points above what was measured; the range from low to high includes it.
By their numbers in this assay, from the lowest: compounds 1, 2, 4 and 3 (each within the scatter of the next).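

Adding compound 4 takes the comparison on the oxygen next to a carbonyl group to a third alkyl group: in this assay, the step of no change at the digits printed from compound 1 to compound 4 (within the scatter) and the step of no change at the digits printed from compound 2 to compound 4 (within the scatter) show that methyl, ethyl and tert-butyl on this carbonyl-oxy group cannot be told apart. Among these compounds, the step of a number 7 percentage points lower from compound 3 to compound 4 (within the scatter) also lies within the scatter, so (2,2,2-trifluoroethoxy)carbonyl and (((methoxycarbonyl)oxy)methoxy)carbonyl cannot be separated either, and all three (alkoxycarbonyl)oxy compounds now stand within the scatter of compound 3, leaving no step in this set that shows a real effect of the group at this position. No data are available to explain this reading.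

The compounds shown leave open whether any replacement at this position can move this assay beyond the scatter, for example an amide in place of the ester or a longer chain such as n-octyl on the oxygen next to a carbonyl group. They also leave open whether the groups that cannot be told apart here would separate at a time shorter than the one stated for this assay.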